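The source may hold more compounds than are shown below. What is called first, only, known or untested is meant among the compounds shown, and "the series" means these compounds.

Measured compounds:
compound 1, `COc1ccc(COCC(Cn2ccnc2)OCCCCC(=O)O)cc1`: 730 nM
compound 2, `COc1ccc(COCC(Cn2ccnc2)OCCCCCC(=O)O)cc1`: 560 nM

Going by the values given here, in a functional assay on a cell-free system (plasma) for inhibition of Thromboxane-A synthase (Homo sapiens) (on this read-out higher numbers stand for weaker inhibition and lower numbers for stronger inhibition), compound 2 gives the lowest of the two numbers, but its only neighbour is close: the step of a 1.3-fold lower number from compound 1 to compound 2 (0.12 log units; within the scatter) lies within the scatter, so the two compounds cannot be told apart on this read-out. Compound 3, `CCOC(=O)CCCCCOC(COCc1ccc(OC)cc1)Cn1ccnc1`, has not yet been measured. It differs from compound 2 in one place: ethyl in place of hydrogen on an oxygen next to a carbonyl group. Among the measured steps, only the one from compound 1 to compound 2 exists, and it changes the length of the chain rather than the acid end, so it gives no direct guide to capping that acid with ethyl. With nothing to lean on, the expectation rests on the change itself: replacing the acid hydrogen with an ethyl group is a small addition, and the estimated step of a 2.5-fold higher number from compound 2 to compound 3 (0.40 log units; beyond the scatter) is expected to be modest, more likely toward a higher number than a lower one. Compound 3 is therefore estimated at 1400 nM, with a range from 400 nM to 5000 nM.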

Compound 3, half-maximal inhibitory concentration: 120 nM
Compound 3: the middle estimate sits 12-fold (1.07 log units) above what was measured; the whole stated range lies above it.
By their numbers in this assay, from the lowest: compound 3; then compounds 2 and 1 (each within the scatter of the next).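

In this assay, the step of a 4.7-fold lower number from compound 2 to compound 3 (0.67 log units; beyond the scatter) shows that this end of the chain responds to change, which the earlier pair could not show, as its step from compound 1 to compound 2 stayed within the scatter. Going from carboxy to (ethoxycarbonyl)methyl gives a 6.1-fold lower number from compound 1 to compound 3 (0.78 log units; beyond the scatter) and points the same way, so among these compounds a free carboxy group is not required for inhibition, and the ethyl-capped compound 3 is the strongest of the three. Nothing available here explains why adding the ethyl group lowers the number.

The compounds shown leave open whether the effect is specific to ethyl, or whether a methyl ester, a primary amide or a tetrazole at the same place would give a similar result. They also leave open whether ethyl capping would lower the number to the same extent on the shorter chain of compound 1, or on a longer chain ending in the same ethoxycarbonyl group.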